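Adding a Chloro Group to a Purine-Type Core

The source may hold more compounds than are shown below. What is called first, only, known or untested is meant among the compounds shown, and "the series" means these compounds.

Measured compounds:
- compound 1, `ClCc1ccc(Cn2cnc3c(Cl)ncnc32)cc1`, 15100 nM
- compound 2, `ClCc1ccccc1Cn1cnc2c(Cl)nc(Cl)nc21`, 2810 nM
- compound 3, `ClCc1cccc(Cn2cnc3ncnc(Cl)c32)c1`, 14800 nM

The three compounds were tested in a functional assay on OVCAR-8 cells (Homo sapiens) for cytotoxicity, read by sulforhodamine B assay, with a stated time of 48 h; on this read-out lower numbers stand for stronger inhibition of growth and higher numbers for weaker inhibition of growth. Compound 3 gives 14800 nM, which places it second highest of the three numbers. Its nearest neighbour is compound 1, whose value of 15100 nM lies within the usual scatter of compound 3, so the two cannot be told apart. Compound 2, with 2810 nM, gives a clearly lower number, beyond the scatter, but it differs from compound 3 in more than one place, so no single cause can be read from that gap.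

The unmeasured compound 4, `ClCc1cccc(Cn2cnc3nc(Cl)nc(Cl)c32)c1`, differs from compound 3 in one place: chloro in place of hydrogen on an aromatic carbon. For the measured compounds named here, no measured pair shows this change alone. Compound 2, which also carries two chloro groups on the core, gives 2810 nM, and this hints that the step from compound 3 to compound 4 may move toward a lower number, though the change in compound 2 is not the same. The expected step of a 2.5-fold lower number from compound 3 to compound 4 (0.39 log units; beyond the scatter) is therefore modest and uncertain. Compound 4 is estimated at 6000 nM, with a range from 2000 nM to 18000 nM.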

Compound 4, concentration for total growth inhibition: 21400 nM
Compound 4: the middle estimate sits 3.6-fold (0.55 log units) below what was measured; measured number outside the range, above it.
By their numbers in this assay, from the lowest: compound 2; then compounds 3, 1 and 4 (each within the scatter of the next).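

Chloro in place of hydrogen on an aromatic carbon, between two ring nitrogen atoms, stands alone in this pair, and in this assay it gives a 1.4-fold higher number from compound 3 to compound 4 (0.16 log units; within the scatter). At this position, then, the added chloro group leaves the two compounds indistinguishable, and the hint of a lower number does not hold for this pair. No independent measurement here bears on the reason for this result.

Going by these compounds, whether a different group on this same carbon, such as an amine or a methoxy group, would give a step beyond the scatter remains open. Also open is what lies behind the value of compound 2, which differs from compound 4 in more than one place, so its number cannot be traced to any single change.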